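This account rests on a few compounds, and the source may have more. Where it says the series, first, only, none or still open, it means among the compounds named here.

Compound 3 `Cc1nc(NC(C2CC2)C2CC2)c2nc(C)n(-c3ccc(OC(F)F)cc3)c2n1` gives 5 nM in a functional assay on CHO cells for antagonist activity at corticotropin-releasing factor receptor 1 (Homo sapiens), read by cAMP accumulation (on this read-out lower numbers stand for stronger inhibition and higher numbers for weaker inhibition), the lowest of the three numbers measured. Compound 1 `Cc1nc(NC(C2CC2)C2CC2)c2nc(C)n(-c3ccc(C#N)cc3)c2n1` gives 62 nM and compound 2 `Cc1nc(NC(C2CC2)C2CC2)c2nc(C)n(-c3ccc(S(C)(=O)=O)cc3)c2n1` gives 140 nM; the steps of a 12-fold lower number from compound 1 to compound 3 (1.09 log units; beyond the scatter) and a 28-fold lower number from compound 2 to compound 3 (1.45 log units; beyond the scatter) lie beyond the scatter, as does a 2.3-fold higher number from compound 1 to compound 2 (0.35 log units; beyond the scatter). Compound 4 `COc1cc(OC(F)F)ccc1-n1c(C)nc2c(NC(C3CC3)C3CC3)nc(C)nc21` differs from compound 3 by methoxy in place of hydrogen on an aromatic carbon. Going by the values given here, none of the measured steps bears directly on this change: all three exchange cyano, methylsulfonyl and difluoromethoxy for one another and none adds a methoxy group, so they offer no guide to its effect. The step of a 1.2-fold higher number from compound 3 to compound 4 (0.08 log units; within the scatter) is therefore expected to stay within the scatter, in no clear direction. Compound 4 is estimated to give about 6 nM, between 2 nM and 18 nM.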

Compound 4, inhibition constant: 0.291 nM
The estimate for compound 4 lay 21-fold (1.31 log units) above the measured number; the measured number lies below the stated range.
By their numbers in this assay, from the lowest: compound 4; then compound 3; then compound 1; then compound 2.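

Adding a methoxy group on the aromatic carbon ortho to a large group and meta to the difluoromethoxy group gives a 17-fold lower number from compound 3 to compound 4 (1.24 log units; beyond the scatter) in this assay. The earlier compounds shown here varied only the group now held by difluoromethoxy, so this shows that a second ring position can also shift the number strongly. Nothing measured here explains the gain. Open questions are whether a fluorine atom, an ethoxy group or a hydroxyl group at this position would act like methoxy, and whether methoxy would have the same effect alongside the nitrile of compound 1.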